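This account rests on a few compounds, and the source may have more. Where it says the series, first, only, none or still open, it means among the compounds named here.

Of the compounds shown here, two of a shared core have been tested in a functional assay on A549 cells (Homo sapiens) for cytotoxicity, read by MTT assay, with a stated time of 72 h; a lower number here means a stronger inhibitor, a higher number a weaker inhibitor. Compound 2, `CCN(CC)CCCOc1c(OCc2ccccc2)cc(O)c2c(=O)cc(-c3ccccc3)oc12`, stands with the higher of the two numbers: in this assay compound 2 gives 3620 nM. Its nearest neighbour is compound 1, `COc1c(OCCCCN2CCN(C)CC2)cc(O)c2c(=O)cc(-c3ccc(Br)cc3)oc12`, for which this assay returns 2130 nM; the gap between them lies within the scatter, so the two values cannot be told apart.

Compound 3, `O=c1cc(-c2ccccc2)oc2c(OCCCCN3CCCC3)c(OCc3ccccc3)cc(O)c12`, awaits measurement. It differs from compound 2 in one place: (pyrrolidin-1-yl)methyl in place of diethylamino on a saturated chain carbon, three bonds along the chain from an oxygen on an aromatic ring. For the measured compounds named here, no pair of measured compounds shows what such a change does, so the expectation rests on compound 2 alone. Compound 3 is expected to give a number close to that of compound 2, with the step of a 1.1-fold lower number from compound 2 to compound 3 (0.05 log units; within the scatter) estimated as none beyond the scatter, in either direction. For compound 3 the estimated value in this assay is 3200 nM, with a range from 1200 nM to 8500 nM.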

Compound 3, half-maximal inhibitory concentration: 1100 nM
Beside the measured number, compound 3's estimate is 2.9-fold (0.46 log units) above it, outside the stated range (below it).
By their numbers in this assay, from the lowest: compounds 3, 1 and 2 (each within the scatter of the next, the first and the last beyond it).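

The change of diethylamino to (pyrrolidin-1-yl)methyl, on a saturated chain carbon, three bonds along the chain from an oxygen on an aromatic ring, gives a 3.3-fold lower number from compound 2 to compound 3 (0.52 log units; beyond the scatter) in this assay. For the compounds shown here, this is the first pair differing in one place, and it shows that the far end of this chain can move the number beyond the scatter, which compounds 1 and 2 alone could not show. Nothing shown here bears on why the number moves.

The same difference also reads as 3-(diethylamino)propyl to 4-(pyrrolidin-1-yl)butyl, so this single step leaves open whether the ring or the longer chain carries the change. As far as these compounds go, a 3-(pyrrolidin-1-yl)propyl or a 4-(diethylamino)butyl chain would separate the two, and how a piperidine or morpholine at the chain end would compare also remains open.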